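Ester series: oxadiazolylphenyl in place of naphthyl

The compounds below may be only part of what the source reports. "The series", "measured", "known", "first", "only" and "open" are said of these compounds alone.

Compound 3 `CCOC(=O)CCCCCOc1cccc(CN(C(=O)c2ccc(-c3cccc4ccccc34)cc2)C(C)C)c1` stands at the top of what has been measured in an ADME assay on BJ cells (Homo sapiens) for cytotoxicity, read by CellTiter-Glo and resazurin assay, with a stated time of 72 h; a higher number here means that more compound is needed for the effect, a lower number that less compound is needed; compound 3 gives > 26000 nM, a limit of the assay rather than a number, and two of the three values shown here are such limits (the limit of > 26000 nM in this assay, at which 2 of the 3 values shown sit). Compound 1 `CC(C)N(Cc1cccc(OCCCCCC(=O)O)c1)C(=O)c1ccc(-c2cccc3ccccc23)cc1` gives < 1.3 nM, also a limit of the assay. Compound 2 `COc1cc(OC)cc(-c2ccc(C(=O)N(Cc3cccc(OCCCCCC(=O)O)c3)C(C)C)cc2)c1` gives > 26000 nM, again a limit. The step of an at least 20000-fold higher number from compound 1 to compound 3 (4.30 log units; beyond the scatter) is large, as is an at least 20000-fold higher number from compound 1 to compound 2 (4.30 log units; beyond the scatter), which swaps out the same naphthalen-1-yl that compound 4 `CCOC(=O)CCCCCOc1cccc(CN(C(=O)c2ccc(-c3cccc(-c4nnc(C)o4)c3)cc2)C(C)C)c1` loses: 3-(5-methyl-1,3,4-oxadiazol-2-yl)phenyl in place of naphthalen-1-yl on an aromatic carbon. Both measured steps push the number up, and compound 3 already sits at the limit, so no return to lower numbers is expected. Compound 4 is expected to give 26000 nM (range 10000 nM to 80000 nM), an expected step of a number no higher from compound 3 to compound 4 (the limit leaves the size open), within the scatter.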

Compound 4, half-maximal effective concentration: > 26000 nM
Compound 4 was reported as a limit; the forecaster's own chance of this, stated with the estimate: 85%; the middle value sits exactly at the limit.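

Among the compounds shown here, compound 3 and compound 4 are both reported as limits of the assay, so no step between them can be read. The compounds shown leave open whether 3-(5-methyl-1,3,4-oxadiazol-2-yl)phenyl and naphthalen-1-yl differ at all in this ester series.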